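A Methoxy Group Added to Compound 2

The compounds below may be only part of what the source reports. "The series", "measured", "known", "first", "only" and "open" are said of these compounds alone.

In an ADME assay on NIH3T3 cells (Mus musculus) for cytotoxicity, read by colorimetric assay and sulforhodamine B assay, with a stated time of 96 h (a higher number here means a weaker inhibitor, a lower number a stronger inhibitor), compound 1 `Oc1cccc(/C=C/c2cc(F)c(F)c(F)c2)c1` gives only a limit, > 30000 nM. Among the measured compounds shown here, compound 2 `Oc1cccc(/C=C/c2cc(O)ccc2O)c1` gives 10500 nM, the only actual number so far in this assay. Compound 3 `COc1ccc(/C=C/c2cc(O)ccc2O)cc1O` differs from compound 2 by methoxy in place of hydrogen on an aromatic carbon, with methoxy in place of hydrogen on an aromatic carbon, ortho to a hydroxy group and para to a large group. For the measured compounds named here, no measured step guides this change, so only a small shift toward stronger inhibition is expected, hardly beyond the scatter, as the estimated 1.9-fold lower number from compound 2 to compound 3 (0.28 log units; within the scatter). For compound 3 the estimate is 5500 nM, with an expected range of 1800 nM to 17000 nM.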

Compound 3, half-maximal inhibitory concentration: > 30000 nM
Compound 3: only a limit was reported; the forecaster's own chance of this, stated with the estimate: 10%; middle value at least 5.4-fold (0.73 log units) from the limit.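

In this assay, among the compounds shown here, methoxy in place of hydrogen on an aromatic carbon, ortho to a hydroxy group and para to a large group, gives an at least 2.8-fold higher number from compound 2 to compound 3 (0.45 log units; beyond the scatter), the first measured step at this position. Compound 3 gives only a limit, > 30000 nM. The step therefore has a known minimum but no known full size, because the reading stops at that limit: the limit of > 30000 nM in this assay, at which 2 of the 3 values shown sit.

The compounds shown leave open how far beyond its limit compound 3 lies. They also leave open whether an amine or a carboxylic acid on this same carbon would shift the number in the same direction.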